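Three amides at the assay limit, and a pyridine to come

The compounds below may be only part of what the source reports. "The series", "measured", "known", "first", "only" and "open" are said of these compounds alone.

Compound 1, `C=CC(=O)Nc1cccc(-c2nc3ccccc3s2)c1`, in an ADME assay on HEK293 cells (Homo sapiens) for inhibition, with a stated time of 72 h (a higher number here means that more compound is needed for the effect, a lower number that less compound is needed), gives > 25000 nM, a limit of the assay.
Compound 2, `C=C(C)C(=O)Nc1cccc(-c2nc3ccccc3s2)c1`, in this assay gives > 25000 nM, again a limit.
Compound 3, `CC(C)(CCl)C(=O)Nc1cccc(-c2nc3ccccc3s2)c1`, in this assay gives > 25000 nM, also a limit.

All three share one core and differ only in the group on the carbonyl carbon of the amide. None of them produced a number: each result is a limit, and so the measured steps a step that the two limits leave unreadable from compound 1 to compound 2, a step that the two limits leave unreadable from compound 1 to compound 3 and a step that the two limits leave unreadable from compound 2 to compound 3 cannot be given a size. Compound 3 therefore stands nowhere in particular on the numbers shown; it stands at the limit together with the other two, which is what the limit of > 25000 nM in this assay, at which 3 of the 3 values shown sit, records.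

Compound 4, `O=C(Nc1cccc(-c2nc3ccccc3s2)c1)c1ccc(Cl)nc1Cl`, carries the change (2,6-dichloropyridin-3-yl in place of 1-(chloromethyl)-1-methylethyl on a carbonyl carbon). No measured step bears on it in a readable way, because the limit of > 25000 nM in this assay, at which 3 of the 3 values shown sit, puts every earlier change among these amides at the same limit. With the amide left untouched, the step that the limit leaves unreadable from compound 3 to compound 4 is expected to stay unreadable rather than to reach a number. Compound 4 is therefore estimated at 35000 nM, with a range from 8000 nM to 150000 nM, most likely reported once more as a limit.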

Compound 4, half-maximal effective concentration: > 25000 nM
Compound 4 was reported as a limit; the forecaster's own chance of this, stated with the estimate: 80%; the middle value is on the limit's open side.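

Compound 4 also returns a limit rather than a number in this assay, so its steps from compound 1, compound 2 and compound 3 cannot be read: the limit of > 25000 nM in this assay, at which 4 of the 4 values shown sit. The compounds shown leave open whether any group on the carbonyl carbon gives a measurable value in this assay, and how far these four groups truly differ.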